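Swapping the Para Substituent: From Chloro to Methyl

The source may report more compounds than this note shows. Statements on the series, on what has been measured and on what is new or still open speak of the compounds shown alone.

Measured compounds:
- compound 1 `CCOc1ccc(NC2=CC(=O)c3ncncc3C2=O)cc1`: 0.16 ug/mL
- compound 2 `O=C1C(Nc2ccc(I)cc2)=CC(=O)c2ncncc21`: 0.27 ug/mL
- compound 3 `O=C1C(Nc2ccc(Cl)cc2)=CC(=O)c2ncncc21`: 0.02 ug/mL

All three share one core and differ only in the group on the outer benzene ring. In a functional assay on A549 cells (Homo sapiens) for cytotoxicity, read by MTT assay, with a stated time of 72 h (a lower number here means a stronger inhibitor, a higher number a weaker inhibitor), compound 3 gives the lowest number of the three, and it is the strongest inhibitor here, since an 8.0-fold lower number from compound 1 to compound 3 (0.90 log units; beyond the scatter) and a 14-fold lower number from compound 2 to compound 3 (1.13 log units; beyond the scatter) both lie beyond the scatter. By contrast a 1.7-fold higher number from compound 1 to compound 2 (0.23 log units; within the scatter) is within the scatter.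

Compound 4 `Cc1ccc(NC2=CC(=O)c3ncncc3C2=O)cc1` has not yet been measured. Its difference from compound 3 is methyl in place of chloro on an aromatic carbon. Among the compounds with values here, no measured step exchanges chloro for methyl, so the nearest guides are the two steps into compound 3, which show that replacing the group at this position can move the number well beyond the scatter. A weaker result than compound 3 is therefore expected for compound 4, but of uncertain size, so the estimate is a 4.0-fold higher number from compound 3 to compound 4 (0.60 log units; beyond the scatter). Compound 4 is expected to give 0.08 ug/mL in this assay, within a range from 0.02 ug/mL to 0.4 ug/mL.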

Compound 4, half-maximal inhibitory concentration: 0.02 ug/mL
The estimate for compound 4 lay 4.0-fold (0.60 log units) above the measured number; the measured number falls inside the stated range.
By their numbers in this assay, from the lowest: compounds 3 and 4 (each within the scatter of the next); then compounds 1 and 2 (each within the scatter of the next).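

Chloro and methyl cannot be told apart at this position in this assay: the swap gives no change at the digits printed from compound 3 to compound 4 (within the scatter). The low number of compound 3 therefore does not depend on a chlorine, and compound 4 keeps the same distance from the other two, with a 14-fold lower number from compound 2 to compound 4 (1.13 log units; beyond the scatter) and an 8.0-fold lower number from compound 1 to compound 4 (0.90 log units; beyond the scatter). The four compounds thus fall into two pairs, chloro and methyl on the low side and iodo and ethoxy on the high side, and no measurement is available to explain this split.

The compounds shown leave open where other groups on this ring would fall, such as an amine, a carboxylic acid or a longer chain. They also leave open whether the methyl result would hold on a different carbon of the same ring.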